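Swapping an aryl group on a fused lactam core

A few compounds are considered here, and "the series" means these few. Any claim that something is new, unique, unknown or untested is made for them only; others in the source may bear on it.

Measured so far:
Compound 2, `CSc1ccc(C2=C(c3ccc(C)c(C)c3)C(=O)N3CCCC3C2)cc1`: 300 nM
Compound 1, `COc1ccc(C2=C(c3cc(OC)c(OC)c(OC)c3)CC3CCCN3C2=O)cc1O`: > 100000 nM

For the measured compounds named here, in a functional assay on SK-OV-3 cells (Homo sapiens) for cytotoxicity (a higher number here means a weaker inhibitor of growth, a lower number a stronger inhibitor of growth), compound 2 gives 300 nM, the only actual number among the values shown here. Compound 1 gives in this assay only > 100000 nM, which is a limit of the assay and not a number (the limit of > 100000 nM in this assay, at which 1 of the 2 values shown sits). Among these two compounds no pair differs in just one place, so the size of a single structural change cannot be read from the measurements themselves.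

Compound 3, `CSc1ccc(C2=C(c3ccc(SC)cc3)C(=O)N3CCCC3C2)cc1`, has not been measured yet. It differs from compound 2 in one place: 4-(methylsulfanyl)phenyl in place of 3,4-dimethylphenyl on a double-bonded ring carbon. After this change both double-bonded ring carbons of the core carry the same 4-(methylsulfanyl)phenyl group. Nothing measured here shows how that group compares with 3,4-dimethylphenyl, so the step expected in this assay from compound 2 to compound 3 is small, none beyond the usual scatter: no change at the digits printed from compound 2 to compound 3 (within the scatter). Compound 3 is therefore expected to give about 300 nM, with a range from 100 nM to 1000 nM.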

Compound 3, concentration for 50% growth inhibition: 2000 nM
Compound 3: the middle estimate sits 6.7-fold (0.82 log units) below what was measured, and the stated range ends below it.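

In this assay, the aryl group on this double-bonded ring carbon clearly matters: putting 4-(methylsulfanyl)phenyl in place of 3,4-dimethylphenyl gives a 6.7-fold higher number from compound 2 to compound 3 (0.82 log units; beyond the scatter), which means weaker growth inhibition. For the compounds shown here, this is the first measured change in a single place, and it shows that swapping one six-membered aromatic carbon ring for another at this position can move the result beyond the usual scatter, even with the other 4-(methylsulfanyl)phenyl group on the core left untouched. None of the information here explains why this swap weakens growth inhibition.

The swap alters two things at once, since the methyl groups of 3,4-dimethylphenyl go and a methylsulfanyl group enters, so a simple 4-methylphenyl or 3-methylphenyl group at this position would be needed to tell which part of the change carries the step. On these data alone, it also remains open how this position would respond to a group of a different kind, such as a phenyl ring bearing an amine or a carboxylic acid, and whether the neighbouring 4-(methylsulfanyl)phenyl group is as sensitive to change.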